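The source may report more compounds than this note shows. Statements on the series, on what has been measured and on what is new or still open speak of the compounds shown alone.

Working notes on the series. Three compounds have numbers: compound 1 `CC(C)(C)OC(=O)N1CCC(O[C@H]2CC[C@H](Oc3ccc(S(C)(=O)=O)cn3)CC2)CC1`, compound 2 `CC(C)(C)OC(=O)N1CCC(O[C@H]2CC[C@H](Oc3cnc(S(C)(=O)=O)cn3)CC2)CC1` and compound 3 `CC(C)S(=O)(=O)c1cnc(O[C@H]2CC[C@H](OC3CCN(C(=O)OC(C)(C)C)CC3)CC2)cn1`; compound 4 `CS(=O)(=O)c1cnc(O[C@H]2CC[C@H](OC3CCN(C(=O)C4(C(F)(F)F)CCCC4)CC3)CC2)cn1` has none yet. In a functional assay on isolated protein for agonist activity at Glucose-dependent insulinotropic receptor (Rattus norvegicus), read by HTRF and cAMP accumulation (on this read-out higher numbers stand for an effect only at larger amounts of compound and lower numbers for an effect already at smaller amounts), compound 1 gives 110 nM, compound 2 gives 64 nM and compound 3 gives 54 nM. Compound 2 sits between the other two, and both of its neighbours lie within the scatter of it. The two measured steps, a 1.7-fold lower number from compound 1 to compound 2 (0.24 log units; within the scatter) and a 1.2-fold lower number from compound 2 to compound 3 (0.07 log units; within the scatter), each concern the heteroaryl ring or the sulfonyl substituent. The change to compound 4 is elsewhere: a group of 9 heavy atoms (6 carbon, 3 fluorine; one five-membered non-aromatic ring of carbon only) in place of a group of 5 heavy atoms (4 carbon, 1 oxygen; no ring), on a carbonyl carbon. Among the measured compounds shown here, no measured step touches this carbonyl carbon, so the data give no direction. For compound 4 the expected result is 60 nM, range 15 nM to 250 nM, which is the estimated step of a 1.1-fold lower number from compound 2 to compound 4 (0.03 log units; within the scatter).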

Compound 4, half-maximal effective concentration: 108 nM
Compound 4: the middle estimate sits 1.8-fold (0.26 log units) below what was measured, within the range that was stated.
By their numbers in this assay, from the lowest: compounds 3, 2, 4 and 1 (each within the scatter of the next, the first and the last beyond it).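

This carbonyl carbon, the first position varied away from the heteroaryl ring and sulfonyl substituent, accepts a much larger group carrying a carbocycle and fluorine, with a 1.7-fold higher number from compound 2 to compound 4 (0.23 log units; within the scatter). Tert-butoxy, with its oxygen, is therefore not required for a number in this range, since the entering group has no hydrogen-bond acceptor. No measurement available bears on the reason for this result. Still open, from the compounds shown here alone, is whether an amine or a cyclopropyl group on this carbonyl carbon would stay within the scatter, and whether isopropyl on the sulfonyl sulfur combines with the new group.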